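Methylation of hydroxy groups in a naphthoquinone amide series

The source may report more compounds than this note shows. Statements on the series, on what has been measured and on what is new or still open speak of the compounds shown alone.

Compound 1 `CC(C)(CNC(=O)c1ccccc1)CC1=C(O)C(=O)c2ccccc2C1=O` gives 15200 nM in a functional assay on KB cells (Homo sapiens) for cytotoxicity, read by resazurin assay, with a stated time of 3 days; a lower number here means a stronger inhibitor, a higher number a weaker inhibitor. Compound 2 `COC1=C(CC(C)(C)CNC(=O)c2ccccc2)C(=O)c2ccccc2C1=O`, which carries methyl in place of hydrogen on an oxygen on an unsaturated carbon, gives 117000 nM; the step of a 7.7-fold higher number from compound 1 to compound 2 (0.89 log units; beyond the scatter). Compound 3 `COc1cc(C(=O)NCC(C)(C)CC2=C(O)C(=O)c3ccccc3C2=O)c(O)c2ccccc12` gives 8620 nM; the difference between the core of compound 3 and the core of compound 1 is not broken down here. Compound 4 `COc1cc(C(=O)NCC(C)(C)CC2=C(O)C(=O)c3ccccc3C2=O)c(OC)c2ccccc12` is unmeasured and carries methyl in place of hydrogen on an oxygen on an aromatic ring. This is the same kind of change as in compound 2, but the place differs: there the oxygen sat on an unsaturated carbon whose other neighbours are a double-bonded ring carbon, here on an aromatic ring whose other neighbours are aromatic carbon. A smaller step is expected for compound 4, a 1.9-fold higher number from compound 3 to compound 4 (0.27 log units; within the scatter), since the weakening seen in a 7.7-fold higher number from compound 1 to compound 2 (0.89 log units; beyond the scatter) concerned the oxygen on the shared core, not the amide-bearing ring. Compound 4 is estimated at 16000 nM, between 6000 nM and 45000 nM.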

Compound 4, half-maximal inhibitory concentration: 47000 nM
Compound 4: middle estimate off by 2.9-fold (0.47 log units), on the low side; the measured number lies above the stated range.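

In this assay the new step, a 5.5-fold higher number from compound 3 to compound 4 (0.74 log units; beyond the scatter), runs the same way as the earlier one, and the two do not differ in size: the same change on two cores in this assay, a 7.7-fold higher number (0.89 log units; beyond the scatter) from compound 1 to compound 2 and a 5.5-fold higher number (0.74 log units; beyond the scatter) from compound 3 to compound 4, 1.4-fold (0.15 log units) apart, within the scatter of two such steps

Within these two pairs, methyl in place of hydrogen on an oxygen therefore carries from one core to the other as a weakening of similar size, although the oxygen sits on an unsaturated carbon in one pair and on an aromatic ring in the other. This rests on two pairs only: it gives no general rule for other cores and no reason why the number rises.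

Open, from the compounds shown here alone, is whether methylating the hydroxy on the unsaturated carbon of compound 3 gives a similar step. Also open, going by these compounds, is whether a longer chain on the oxygen, or an amine in place of the hydroxy, would follow methyl.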